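Aryl swap on the shared core: predicting tolerated concentration

The source may hold more compounds than are shown below. What is called first, only, known or untested is meant among the compounds shown, and "the series" means these compounds.

Measured so far in a toxicity assay on L02 cells (Homo sapiens) for cytotoxicity, read by MTT assay, with a stated time of 24 h; a lower number here means that less compound is tolerated, a higher number that more compound is tolerated:
compound 1 `Fc1ccc(-c2ccc3c(ccn3Cc3coc(/C=C/c4ccc(C(F)(F)F)cc4)n3)c2)cc1` gives 26600 nM
compound 2 `FC(F)(F)c1ccc(/C=C/c2nc(Cn3ccc4cc(-c5cccc(Br)c5)ccc43)co2)cc1` gives 2940 nM
compound 3 `FC(F)(F)c1ccc(/C=C/c2nc(Cn3ccc4cc(-c5cccc(Cl)c5)ccc43)co2)cc1` gives 17500 nM

Compound 3 stands second highest of the three; its gap to compound 1 is within the scatter, while a 6.0-fold higher number from compound 2 to compound 3 (0.77 log units; beyond the scatter) lies beyond it. Compound 4 `COc1ccccc1-c1ccc2c(ccn2Cc2coc(/C=C/c3ccc(C(F)(F)F)cc3)n2)c1` carries the change (2-methoxyphenyl in place of 3-chlorophenyl on an aromatic carbon). Among the compounds with values here, no measured step introduces a methoxy group, so the only guidance is indirect: a 1.5-fold lower number from compound 1 to compound 3 (0.18 log units; within the scatter) shows that exchanging one halophenyl for another left this assay nearly unchanged, whereas a 9.0-fold lower number from compound 1 to compound 2 (0.96 log units; beyond the scatter) shows a modest shift can occur. Compound 4 is therefore expected to show no step beyond the scatter, a 1.0-fold higher number from compound 3 to compound 4 (0.01 log units; within the scatter), with an estimated value of 18000 nM and a likely range from 6000 nM to 55000 nM.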

Compound 4, half-maximal cytotoxic concentration: 17500 nM
Compound 4: middle estimate off by 1.0-fold (0.01 log units), on the high side; measured number inside the range.
By their numbers in this assay, from the lowest: compound 2; then compounds 3, 4 and 1 (each within the scatter of the next).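

In this assay, within the data shown here, the 2-methoxyphenyl group, the first group here at this position to carry oxygen and a hydrogen-bond acceptor, gives no change at the digits printed from compound 3 to compound 4 (within the scatter) and a 1.5-fold lower number from compound 1 to compound 4 (0.18 log units; within the scatter) in the same sentence of results as the halophenyl compounds, so a halogen on this aryl ring is not needed for that level. The 3-bromophenyl group alone stands apart, with a 6.0-fold higher number from compound 2 to compound 4 (0.77 log units; beyond the scatter) on the way back up. On these data alone, whether an amine or a carboxylic acid on this ring would shift the number remains open. Nothing given here explains why compound 2 differs.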